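A few compounds are considered here, and "the series" means these few. Any claim that something is new, unique, unknown or untested is made for them only; others in the source may bear on it.

Measured so far:
- compound 1 `CCCCCCCCCCc1ccccc1C(SCCC(=O)O)SCCC(=O)O` — 1180 nM
- compound 2 `CCCCc1ccccc1C(SCCC(=O)O)SCCC(=O)O` — in this read-out, a limit: > 20000 nM
- compound 3 `O=C(O)CCSC(SCCC(=O)O)c1ccccc1CCCCCCCCCCCC(F)(F)F` — 147 nM

These three compounds share one core and differ only in the chain that hangs from its aromatic ring. In an assay on membranes from lung (Cavia porcellus) for binding affinity to cysteinyl leukotriene receptor (Homo sapiens) (on this read-out higher numbers stand for weaker inhibition and lower numbers for stronger inhibition), compound 1 gives 1180 nM. Compound 2 reaches only the limit of this assay, > 20000 nM, so for it no number is known (the limit of > 20000 nM in this assay, at which 1 of the 3 values shown sits). Compound 3 gives 147 nM, which is the lowest of the two numbers shown, with compound 1 the nearest at an 8.0-fold lower number from compound 1 to compound 3 (0.90 log units; beyond the scatter).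

The steps show how much the chain matters: cutting it back, an at least 16-fold higher number from compound 1 to compound 2 (1.22 log units; beyond the scatter), and extending its far end with a fluorinated group, an 8.0-fold lower number from compound 1 to compound 3 (0.90 log units; beyond the scatter) and an at least 130-fold lower number from compound 2 to compound 3 (2.13 log units; beyond the scatter).

Compound 4 `O=C(O)CCSC(SCCC(=O)O)c1ccccc1CCCCCCCCC1CCCCC1` keeps the core and changes the end of the chain: cyclohexyl in place of 4,4,4-trifluorobutyl on a saturated chain carbon, eight bonds along the chain from an aromatic carbon. For the measured compounds named here, no measured step tests a ring at the chain end, and the chain of compound 4 is a little shorter than that of compound 3. Given the gain from the fluorinated end in the step from compound 1 to compound 3, compound 4 is expected to lose part of that gain, estimated at a 2.7-fold higher number from compound 3 to compound 4 (0.43 log units; beyond the scatter), giving an estimate of 400 nM with a range from 100 nM to 1800 nM.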

Compound 4, inhibition constant: 1960 nM
Compound 4: middle estimate off by 4.9-fold (0.69 log units), on the low side; measured number above the stated range.
By their numbers in this assay, from the lowest: compound 3; then compounds 1 and 4 (each within the scatter of the next). At a limit, above all of these: compound 2.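

In this assay, a ring at the chain end does not keep what the 4,4,4-trifluorobutyl end provides, with a 13-fold higher number from compound 3 to compound 4 (1.12 log units; beyond the scatter), so the gain seen with compound 3 does not carry over to every group placed at this end of the chain. The ring-ended chain instead falls level with the plain alkyl chain, with a 1.7-fold higher number from compound 1 to compound 4 (0.22 log units; within the scatter), and this places the cyclohexyl end alongside the unfluorinated chain end rather than alongside the fluorinated one. The length of the chain still counts with the ring in place, with an at least 10-fold lower number from compound 2 to compound 4 (1.00 log units; beyond the scatter), and the value for compound 2 in that step is a limit and not a number: the limit of > 20000 nM in this assay, at which 1 of the 4 values shown sits.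

The compounds shown leave open whether the gain belongs to the three fluorine atoms themselves or to the particular length of the chain that carries them, and a shorter or longer chain ending in trifluoromethyl would help to separate the two. They also leave open whether any ring can be tolerated at this end, such as a phenyl ring or a cyclohexyl group on a longer chain.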